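Branching the Amide Chain: From Compound 3 to Compound 4

This account rests on a few compounds, and the source may have more. Where it says the series, first, only, none or still open, it means among the compounds named here.

Compound 1 `O=C(NCC1CCOCC1)c1cc(-n2ncc(=O)[nH]c2=O)ccc1Cl`, compound 2 `CCCCCNC(=O)c1cc(-n2ncc(=O)[nH]c2=O)ccc1Cl` and compound 3 `CCCCCCNC(=O)c1cc(-n2ncc(=O)[nH]c2=O)ccc1Cl` share one core and differ only in the chain on the amide nitrogen. In a functional assay on cells for antagonist activity at P2X purinoceptor 7 (Homo sapiens), read by ELISA (a lower number here means a stronger inhibitor, a higher number a weaker inhibitor), compound 1 gives only a limit, > 5000 nM. Compound 2 gives 2800 nM, while compound 3 gives 3600 nM; the step of a 1.3-fold higher number from compound 2 to compound 3 (0.11 log units; within the scatter) lies within the scatter, so the two stand together. The steps of an at least 1.7-fold lower number from compound 1 to compound 2 (0.25 log units; that floor lies within the scatter) and an at least 1.3-fold lower number from compound 1 to compound 3 (0.14 log units; that floor lies within the scatter) have floors that also lie within the scatter. Compound 4 `CCC(CC)CNC(=O)c1cc(-n2ncc(=O)[nH]c2=O)ccc1Cl` keeps the same atoms joined differently: pentan-3-yl in place of pentyl on a saturated chain carbon bound to an amide-type nitrogen. Among the measured compounds shown here, no measured step rearranges a chain this way, and the chain steps seen so far stayed within the scatter, so no change beyond the scatter is expected. Compound 4 is estimated at 3600 nM, between 1500 nM and 8000 nM, an expected step of no change at the digits printed from compound 3 to compound 4 (within the scatter).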

Compound 4, half-maximal inhibitory concentration: 1100 nM
Compound 4: the middle estimate sits 3.3-fold (0.51 log units) above what was measured; the whole stated range lies above it.
By their numbers in this assay, from the lowest: compound 4; then compounds 2 and 3 (each within the scatter of the next). At a limit, above all of these: compound 1.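

In this assay, joining the same atoms differently moves the number beyond the scatter: a 3.3-fold lower number from compound 3 to compound 4 (0.51 log units; beyond the scatter). The branched chain also stands apart from the shorter straight one, with a 2.5-fold lower number from compound 2 to compound 4 (0.41 log units; beyond the scatter), so the shape of this chain matters here, which the straight chains alone could not show. The step against oxan-4-yl is only a floor, an at least 4.5-fold lower number from compound 1 to compound 4 (0.65 log units; beyond the scatter), since compound 1 gives a limit: the limit of > 5000 nM in this assay, at which 1 of the 4 values shown sits.

Going by these compounds, whether a cyclohexyl group or a longer branched chain would lower the number further stays open. So does whether an amine in the chain would keep this gain.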